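The source may report more compounds than this note shows. Statements on the series, on what has been measured and on what is new or still open speak of the compounds shown alone.

Working notes on the cytotoxicity series. Compound 1 `O=C(/C=C/c1ccc(N2CCCCC2)cc1)c1cccs1` and compound 2 `O=C(/C=C/c1ccc(N2CCCCC2)cc1)c1ccsc1` share one core and differ only in the thiophene attached to the carbonyl carbon. In an ADME assay on PBMC cells (Homo sapiens) for cytotoxicity, with a stated time of 5 days (on this read-out higher numbers stand for weaker inhibition and lower numbers for stronger inhibition), compound 1 gives > 100000 nM, which is a limit of the assay and not a number. Compound 2 in this assay gives > 100000 nM, again a limit of the assay. The step that the two limits leave unreadable from compound 1 to compound 2 is therefore not readable. Both values sit at the limit of > 100000 nM in this assay, at which 2 of the 2 values shown sit, so compound 2 stands at the limit and nowhere more precise.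

Compound 3 `Cc1ccsc1C(=O)/C=C/c1ccc(N2CCCCC2)cc1` is the next member. It differs from compound 2 by 3-methylthiophen-2-yl in place of thiophen-3-yl on a carbonyl carbon. Within the data shown here, the only measured step that bears on this change is the one from compound 1 to compound 2, and its size cannot be read, so no direction is expected beyond the scatter and the reasonable working expectation in this assay is another limit. The step that the limit leaves unreadable from compound 2 to compound 3 is estimated as no change. For compound 3 the estimate in this assay is 150000 nM, with a range from 50000 nM to 500000 nM.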

Compound 3, half-maximal inhibitory concentration: 26400 nM
Compound 3: middle estimate off by 5.7-fold (0.75 log units), on the high side; the whole stated range lies above it.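

In this assay compound 3 is the first member of the series to give a measured number and not a limit, so the thiophene on the carbonyl carbon is now shown to be a place where this read-out can move. Methyl in place of hydrogen on an aromatic carbon is the smallest change that does this, giving an at least 3.7-fold lower number from compound 1 to compound 3 (0.57 log units; beyond the scatter), and 3-methylthiophen-2-yl in place of thiophen-3-yl gives an at least 3.7-fold lower number from compound 2 to compound 3 (0.57 log units; beyond the scatter). Both steps are bounds on size and not sizes, and the series still reads as one number against two limits: the limit of > 100000 nM in this assay, at which 2 of the 3 values shown sit.

From the compounds shown here alone, the full size of either step stays unknown, and a single methyl-bearing compound cannot separate the effect of the methyl group itself from that of its place on the thiophene. Going by these compounds, whether ethyl or a chlorine atom in the place of that methyl, or a methyl group on the thiophen-3-yl member, would also lower the number remains open.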